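Lengthening the Chain from Compound 2 to Compound 3

The compounds below may be only part of what the source reports. "The series", "measured", "known", "first", "only" and "open" are said of these compounds alone.

Measured in a functional assay, read by spectrophotometry, with a stated time of 6 min; on this read-out higher numbers stand for weaker inhibition and lower numbers for stronger inhibition:
compound 1 `CCCCCCCCCCOc1cc(OC)c(Br)cc1C(C)=O`: 34700000 nM
compound 2 `CCCCCCCCCCCCCCOc1cc(OC)c(Br)cc1C(C)=O`: 8700000 nM

Of these two, compound 2 has the lower number, and so the stronger inhibition. Compound 3 `CCCCCCCCCCCCCCCCOc1cc(OC)c(Br)cc1C(C)=O` differs from it as follows: ethyl in place of hydrogen on a saturated chain carbon, ten or more bonds along the chain from an oxygen on an aromatic ring. Ethyl replaces hydrogen on a saturated chain carbon. Within the data shown here, one measured step bears on this change, the one with butyl in place of hydrogen at such a carbon: a 4.0-fold lower number from compound 1 to compound 2 (0.60 log units; beyond the scatter). Ethyl is a smaller addition than butyl, so a smaller step in the same direction is expected in this assay, although a single step cannot show that the trend continues. The expected step is a 1.9-fold lower number from compound 2 to compound 3 (0.29 log units; within the scatter). Compound 3 is estimated at 4500000 nM, with an expected range of 1800000 nM to 11000000 nM.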

Compound 3, half-maximal inhibitory concentration: 4600000 nM
Compound 3: the middle estimate sits 1.0-fold (0.01 log units) below what was measured; the range from low to high includes it.
By their numbers in this assay, from the lowest: compounds 3 and 2 (each within the scatter of the next); then compound 1.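

With ethyl in place of hydrogen on this saturated chain carbon, this assay gives a 1.9-fold lower number from compound 2 to compound 3 (0.28 log units; within the scatter), so this further addition cannot be told apart from the ordinary variation between repeat measurements. Only the larger change, hexyl in place of hydrogen, clearly stands out, with a 7.5-fold lower number from compound 1 to compound 3 (0.88 log units; beyond the scatter). Going by these compounds, whether a longer chain would give a still lower number, or an amine or a carboxylic acid on this chain a different one, stays open. No measurement shown gives a reason for these numbers.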